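The source may hold more compounds than are shown below. What is called first, only, known or untested is meant among the compounds shown, and "the series" means these compounds.

Compound 1 `CN(C)CCNc1nc(-c2ccc(NC(=O)Nc3ccc(Cl)cc3)cc2)nc2c(Cl)c(Cl)sc12` and compound 2 `CN(C)CCNc1nc(-c2ccc(NC(=O)Nc3ccccc3Cl)cc2)nc2c(Cl)c(Cl)sc12` are built on one core; compound 3 `CCN(CC)CCNc1nc(-c2ccc(NC(=O)Nc3ccc(Cl)cc3)cc2)nc2ccsc12` and compound 4 `CCN(CC)CCNc1nc(-c2ccc(NC(=O)Nc3ccccc3Cl)cc2)nc2ccsc12` are built on another, and the difference between the two cores is not broken down here. In a functional assay on NCI-H460 cells (Homo sapiens) for cytotoxicity, read by MTT assay, with a stated time of 72 h (on this read-out higher numbers stand for weaker inhibition and lower numbers for stronger inhibition), compound 1 gives 300 nM and compound 2 gives 440 nM. The change from compound 1 to compound 2 is 2-chlorophenyl in place of 4-chlorophenyl on an amide-type nitrogen and it made a 1.5-fold higher number from compound 1 to compound 2 (0.17 log units; within the scatter). In this assay compound 3 gives 190 nM. Compound 4 has no number yet in this assay. The change from compound 3 to compound 4 is 2-chlorophenyl in place of 4-chlorophenyl on an amide-type nitrogen, made at a place described in the same words as for compound 1 and compound 2, so it is the same change carried onto the other core. Going by the values given here, the step from compound 3 to compound 4 in this assay is expected to be about a 1.5-fold higher number from compound 3 to compound 4 (0.17 log units; within the scatter), because a 1.5-fold higher number from compound 1 to compound 2 (0.17 log units; within the scatter) stayed within the scatter and no other measured pair speaks against carrying that over. Compound 4 in this assay is therefore estimated at 280 nM, with a likely range from 150 nM to 550 nM.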

Compound 4, half-maximal inhibitory concentration: 320 nM
Estimate against measurement, compound 4: 1.1-fold (0.06 log units) below, within the range that was stated.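

The step from swapping 4-chlorophenyl for 2-chlorophenyl on the amide-type nitrogen reads a 1.7-fold higher number from compound 3 to compound 4 (0.23 log units; within the scatter) in this assay. Set beside the earlier step, the change carries from one core to the other with no difference in size that can be told apart: the same change on two cores in this assay, a 1.5-fold higher number (0.17 log units; within the scatter) from compound 1 to compound 2 and a 1.7-fold higher number (0.23 log units; within the scatter) from compound 3 to compound 4, 1.1-fold (0.06 log units) apart, within the scatter of two such steps. This holds for these two cores and this cell read-out only, and since each step stays within the scatter, the agreement is between two small steps; it does not show how a change with a larger step would carry over, or that this one would carry onto a third core.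

Still open, going by these compounds, is whether a phenyl bearing trifluoromethyl or methoxy in place of chlorine on the amide-type nitrogen would carry over in the same way. Also open, on these data alone, is how the same change would fare with a morpholine in place of the terminal dimethylamino or diethylamino group.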